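Fluorobenzyl triazole chalcones: growth inhibition working notes

A few compounds are considered here, and "the series" means these few. Any claim that something is new, unique, unknown or untested is made for them only; others in the source may bear on it.

Measured so far:
compound 1, `O=C(/C=C/c1ccc(OCc2cn(Cc3cccc(F)c3)nn2)cc1)c1ccc(Br)cc1`: 34%
compound 2, `O=C(/C=C/c1ccc(OCc2cn(Cc3ccc(F)cc3)nn2)cc1)c1ccc(Br)cc1`: 32%
compound 3, `O=C(/C=C/c1ccc(OCc2cn(Cc3cccc(F)c3)nn2)cc1)c1ccc([N+](=O)[O-])cc1`: 32%

All three numbers come from a functional assay on MIA PaCa-2 cells (Homo sapiens) for inhibition, read by MTT assay, with a stated time of 48 h, tested at 10 uM; on this read-out higher numbers stand for more inhibition of growth at the one concentration tested and lower numbers for less inhibition of growth. Compound 1 and compound 2 differ by 4-fluorophenyl in place of 3-fluorophenyl on a saturated chain carbon bound to an aromatic nitrogen, and the step is a number 2 percentage points lower from compound 1 to compound 2 (within the scatter). Compound 1 and compound 3 differ by nitro in place of bromo on an aromatic carbon, with the step of a number 2 percentage points lower from compound 1 to compound 3 (within the scatter). Compound 2 and compound 3 show the same value at the digits given.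

Compound 4, `O=C(/C=C/c1ccc(OCc2cn(Cc3ccc(F)cc3)nn2)cc1)c1ccc([N+](=O)[O-])cc1`, has not been measured. It differs from compound 3 by 4-fluorophenyl in place of 3-fluorophenyl on a saturated chain carbon bound to an aromatic nitrogen, the same change as between compound 1 and compound 2, made on a core that differs from that of compound 1 by nitro in place of bromo on an aromatic carbon. Since the earlier step of a number 2 percentage points lower from compound 1 to compound 2 (within the scatter) stayed within the scatter, a step of a number 2 percentage points lower from compound 3 to compound 4 (within the scatter) is expected from compound 3 to compound 4 in this assay. The estimate for compound 4 is therefore 30%, with a likely range from 20% to 40%.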

Compound 4, percent growth inhibition at one concentration: 44%
Compound 4: the middle estimate sits 14 percentage points below what was measured; the measured number lies above the stated range.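

In this assay, 4-fluorophenyl in place of 3-fluorophenyl gives a number 12 percentage points higher from compound 3 to compound 4 (beyond the scatter), and nitro in place of bromo gives a number 12 percentage points higher from compound 2 to compound 4 (beyond the scatter). Each step is beyond the scatter on its own, but neither change is shown to depend on the core: the same change on two cores in this assay, a number 2 percentage points lower (within the scatter) from compound 1 to compound 2 and a number 12 percentage points higher (beyond the scatter) from compound 3 to compound 4, 14 percentage points apart, within the scatter of two such steps. The nitro change reads the same way, and compound 4 alone carries the higher number in both comparisons, so no dependence on the core is established and none is ruled out: the same change on two cores in this assay, a number 2 percentage points lower (within the scatter) from compound 1 to compound 3 and a number 12 percentage points higher (beyond the scatter) from compound 2 to compound 4, 14 percentage points apart, within the scatter of two such steps.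

Still open, from the compounds shown here alone, is whether these steps hold with an amine or a carboxylic acid in place of the bromo or nitro group, or with a longer chain in place of the fluorobenzyl. Going by these compounds, with one concentration tested, the response across concentrations also remains open.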